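This account rests on a few compounds, and the source may have more. Where it says the series, first, only, none or still open, it means among the compounds named here.

Compound 1 `N=C(NCCCc1c[nH]cn1)NCCCC(c1ccc(F)cc1)c1ccccn1` — 0.9
Compound 2 `COc1ccc(C(CC/N=C(\N)NCCCc2c[nH]cn2)c2ccccn2)cc1` — 1
Compound 3 `N=C(NCCCc1c[nH]cn1)NCCC(c1ccc(C(F)(F)F)cc1)c1ccccn1` — 0.9

In a functional assay on cardiac atrium for agonist activity at histamine H2 receptor (Cavia porcellus) (a higher number here means a larger maximal response, a lower number a smaller maximal response), compound 3 gives 0.9. Compound 1 sits level with it at the digits shown, giving 0.9. Compound 2 gives 1, and the gap from compound 3 to compound 2 lies within the usual scatter of repeated measurements, so the three compounds show no separation that can be read as a real difference. All three share the same core and differ only in the aryl group on the saturated chain carbon.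

Compound 4 `N=C(NCCCc1c[nH]cn1)NCCC(c1ccccn1)c1cccs1` has not yet been measured in this assay. It differs from compound 3 by thiophen-2-yl in place of 4-(trifluoromethyl)phenyl on a saturated chain carbon bound to an aromatic carbon and a saturated chain carbon.

Because the values of compound 1, compound 2 and compound 3 all sit within the scatter of each other, the step of no change at the digits printed from compound 3 to compound 4 (within the scatter) is expected to be none beyond the scatter. Compound 4 is therefore estimated at 0.9, with a range from 0.7 to 1.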

Compound 4, intrinsic activity: the largest response reached, as a fraction of the reference agonist's: 1
Beside the measured number, compound 4's estimate is 0.10 below it; low and high end bracket the measured number.
By their numbers in this assay, from the lowest: compounds 1, 3, 2 and 4 (each within the scatter of the next).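

For the compounds shown here, compounds 3 and 4 form the first pair here that differs in one place, and in this assay the exchange of 4-(trifluoromethyl)phenyl for thiophen-2-yl on a saturated chain carbon bound to an aromatic carbon and a saturated chain carbon gives a number 0.10 higher from compound 3 to compound 4 (within the scatter). At this position, then, the maximal response does not separate a six-membered aromatic ring of carbon only, with 10 heavy atoms, from a five-membered aromatic ring with 1 hetero atom and 5 heavy atoms. No measurement at hand accounts for this result.

The compounds shown leave open whether a group without an aromatic ring, such as cyclohexyl, would keep the response at this position. They also leave open what a carboxylic acid or an amine on the aromatic ring would do there.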